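The compounds below may be only part of what the source reports. "The series", "measured", "known", "first", "only" and "open" are said of these compounds alone.

Compound 2 `COc1cc(-c2cccc3nc(-c4cccc(Cl)c4)oc23)cc(OC)c1OC` carries a 3-chlorophenyl on the shared core. In a functional assay on A549 cells (Homo sapiens) for antiproliferative activity, read by MTT assay, with a stated time of 48 h (on this read-out higher numbers stand for weaker inhibition and lower numbers for stronger inhibition), compound 2 reaches only a limit, > 25000 nM, and no number beyond it is known. That limit is the one at which (the limit of > 25000 nM in this assay, at which 1 of the 3 values shown sits), so compound 2 stands at the weak end of what this series shows. Among the compounds with values here, compound 1 `COc1ccc(-c2nc3cccc(-c4cc(OC)c(OC)c(OC)c4)c3o2)cc1` differs in one place and gives 2200 nM in this assay; the step of an at least 11-fold higher number from compound 1 to compound 2 (1.05 log units; beyond the scatter) is the only measured step and marks that position as one where the group chosen changes the outcome. Compound 3 `COc1ccc(-c2cccc3nc(-c4ccc5cc[nH]c5c4)oc23)c(OC)c1OC`, which carries an indolyl group and a differently arranged trimethoxyphenyl, gives 9600 nM in this assay.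

Compound 4 `COc1cc(-c2cccc3nc(-c4ccco4)oc23)cc(OC)c1OC` is not yet measured. It differs from compound 2 by furan-2-yl in place of 3-chlorophenyl on an aromatic carbon. Within the data shown here, the one measured step at this position ran in the weakening direction when 3-chlorophenyl entered, so a return to a smaller, oxygen-bearing aromatic ring may be expected to move the number down again, though with wide uncertainty, since compound 2 sets only a limit. For compound 4 the expected change is an at least 1.6-fold lower number from compound 2 to compound 4 (0.22 log units; that floor lies within the scatter). Compound 4 is therefore estimated at 15000 nM, with a plausible range from 4000 nM to 60000 nM in this assay.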

Compound 4, half-maximal inhibitory concentration: 10300 nM
Beside the measured number, compound 4's estimate is 1.5-fold (0.16 log units) above it, within the range that was stated.
By their numbers in this assay, from the lowest: compound 1; then compounds 3 and 4 (each within the scatter of the next). At a limit, above all of these: compound 2.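

With furan-2-yl in place of 3-chlorophenyl, this assay shows an at least 2.4-fold lower number from compound 2 to compound 4 (0.38 log units; beyond the scatter), so replacing 4-methoxyphenyl at this position does not always take the number to the limit of the assay. That step gives only a floor, and its true size cannot be read, as compound 2 stands at a limit: the limit of > 25000 nM in this assay, at which 1 of the 4 values shown sits. Furan-2-yl still does not match 4-methoxyphenyl, with a 4.7-fold higher number from compound 1 to compound 4 (0.67 log units; beyond the scatter), so among the three groups on this aromatic carbon, next to the ring nitrogen and the ring oxygen, 4-methoxyphenyl gives the lowest number and furan-2-yl an intermediate one.

The compounds shown do not separate the ring oxygen of furan-2-yl from the change to a five-membered ring, a question that a thiophen-2-yl or an unsubstituted phenyl group at this carbon would bear on. They also leave open how an aminophenyl or a carboxylic acid on the aryl ring would read, and whether the same order of groups holds with the differently arranged trimethoxyphenyl of compound 3.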